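A few compounds are considered here, and "the series" means these few. Any claim that something is new, unique, unknown or untested is made for them only; others in the source may bear on it.

In an ADME assay on cells (Hepatocyte, Mus musculus) for pharmacokinetics (on this read-out lower numbers stand for slow clearance and higher numbers for fast clearance), compound 1 `Cc1cc(NC(=O)Cn2nnc(-c3ccccc3)n2)n(C2CCCCC2)n1` gives 87 mL/min/kg. Compound 3 `Cc1cc(NC(=O)Cn2nnc(-c3ccccc3)n2)n(CC2CCCCC2)n1` gives 88.7 mL/min/kg. Swapping cyclohexyl for cyclohexylmethyl on the aromatic nitrogen gives a 1.0-fold higher number from compound 1 to compound 3 (0.01 log units; within the scatter), so these two compounds stand level. Compound 2 `Cc1cc(NC(=O)Cn2nnc(-c3ccccc3)n2)n(C2CCS(=O)(=O)C2)n1` has only a limit, < 31.9 mL/min/kg. Placing 1,1-dioxothiolan-3-yl on that nitrogen instead gives an at least 2.7-fold lower number from compound 1 to compound 2 (0.43 log units; beyond the scatter), a step beyond the scatter.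

Compound 4 `Cc1cc(NC(=O)Cn2nnc(-c3cccc(F)c3)n2)n(C2CCCCC2)n1` keeps the cyclohexyl group of compound 1 and changes the other end of the molecule: fluoro in place of hydrogen on an aromatic carbon, with fluoro in place of hydrogen on an aromatic carbon. Neither measured step touches this phenyl group, so both bear on it only indirectly. They show that the number can move with one change on the nitrogen, as in an at least 2.7-fold lower number from compound 1 to compound 2 (0.43 log units; beyond the scatter), but they give no size for a fluoro change. With no measured sign of a shift, the expected change is a 1.1-fold lower number from compound 1 to compound 4 (0.03 log units; within the scatter), an estimated step within the scatter. Compound 4 is expected to give about 82 mL/min/kg, with an estimated range from 55 mL/min/kg to 110 mL/min/kg.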

Compound 4, clearance: 87.1 mL/min/kg
The estimate for compound 4 lay 1.1-fold (0.03 log units) below the measured number, within the range that was stated.
By their numbers in this assay, from the lowest: compounds 1, 4 and 3 (each within the scatter of the next). At a limit, below all of these: compound 2.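

The first change shown at the phenyl end of the molecule leaves clearance in this assay where it was: a 1.0-fold higher number from compound 1 to compound 4 (0.00 log units; within the scatter). So, with cyclohexyl on the aromatic nitrogen, a fluoro on an aromatic carbon meta to a large group, which turns phenyl into 3-fluorophenyl, does not separate compound 4 from compound 1, while the earlier compounds had varied only the group on that nitrogen. Nothing shown here explains why this swap leaves the number in place.

On these data alone, whether a larger or very different group at the same place, such as an amine, a carboxylic acid or a methoxy group, would also leave the number in place remains open. So does whether the fluoro would behave the same way on compound 2, which carries the 1,1-dioxothiolan-3-yl group.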